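The source may report more compounds than this note shows. Statements on the series, on what has been measured and on what is new or still open speak of the compounds shown alone.

For the measured compounds named here, compound 3, `Clc1ccc(C2=NN(C3=NC(c4ccccc4)CS3)C(c3cccc4ccccc34)C2)cc1`, stands at the top of the three numbers so far in a functional assay on HeLa cells (Homo sapiens) for inhibition, read by CCK-8 assay, with a stated time of 48 h; on this read-out lower numbers stand for stronger inhibition and higher numbers for weaker inhibition: compound 3 gives 9940 nM. Going by the values given here, its nearest neighbour is compound 2, `Brc1ccc(C2=NN(C3=NC(c4ccccc4)CS3)C(c3cccc4ccccc34)C2)cc1`, which in this assay gives 6650 nM; the step of a 1.5-fold higher number from compound 2 to compound 3 (0.17 log units; within the scatter) is the only one-point change measured here and sits inside the scatter. Furthest away is compound 1, `COc1ccc(C2=NN(C3=NC(=O)CS3)C(c3cccc4ccccc34)C2)cc1`, which in this assay gives 2540 nM, a gap beyond the scatter, but compound 1 differs from compound 3 in two places and so offers no isolated reading of either change.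

Compound 4, `COc1ccc(C2=NN(C3=NC(c4ccccc4)CS3)C(c3cccc4ccccc34)C2)cc1`, is compound 3 with one change: methoxy in place of chloro on an aromatic carbon.

Among the compounds with values here, no measured step tests methoxy in place of chloro on an aromatic carbon on its own. Within the data shown here, the one measured step, from compound 2 to compound 3, exchanges one halogen for another and stayed within the scatter, so it says little about a methoxy group. That compound 1 carries the methoxy group and gives the lowest number is suggestive, yet its second difference from compound 3 leaves the source of that gap open. The step is therefore expected to be a 2.0-fold lower number from compound 3 to compound 4 (0.30 log units; within the scatter), towards a lower number but with wide uncertainty. Compound 4 is estimated in this assay at 5000 nM, within a range from 1800 nM to 14000 nM.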

Compound 4, half-maximal inhibitory concentration: 3310 nM
For compound 4 the middle estimate is 1.5-fold (0.18 log units) above the measured one; measured number inside the range.
By their numbers in this assay, from the lowest: compounds 1, 4, 2 and 3 (each within the scatter of the next, the first and the last beyond it).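

In this assay, for the compounds shown here, replacing 4-chlorophenyl with 4-methoxyphenyl, para to a large group, gives a 3.0-fold lower number from compound 3 to compound 4 (0.48 log units; beyond the scatter), the first one-point change at this position to clear the scatter and so the first sign that the group here can matter. The bromo compound does not stand clearly apart from either neighbour: alongside the halogen exchange already measured, the methoxy change gives a 2.0-fold lower number from compound 2 to compound 4 (0.30 log units; within the scatter), so only the chloro and methoxy compounds are separated at this position. With methoxy held constant, exchanging the group on the ring amine nitrogen gives a 1.3-fold higher number from compound 1 to compound 4 (0.11 log units; within the scatter), so the larger group of compound 4 and the smaller group of compound 1 cannot be told apart in this assay when this substituent is present.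

No supporting evidence bears on why the methoxy step occurs. As far as these compounds go, it remains open whether a hydroxyl, an amine or a carboxylic acid at this position would extend or reverse the step, and whether the chloro-to-methoxy difference would hold on the core of compound 1.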